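Ethyl on the Amide Nitrogen: Expectation for Compound 3

The source may report more compounds than this note shows. Statements on the series, on what has been measured and on what is new or still open speak of the compounds shown alone.

Compound 2 `CCNC(=O)C1=C(C)NC(=O)NC1c1ccoc1` is one of two compounds measured in an assay on membranes from HeLa cells for displacement of a labelled ligand from adenosine receptor A3 (Homo sapiens), read by scintillation counting, with a stated time of 180 min, tested at 1 uM (a lower number here means less inhibition, a higher number more inhibition at the concentration tested (going by the name of the read-out)), where compound 2 gives 1%, the lower of the two numbers shown, though the gap to the other lies within the scatter. Compound 1 `CCCC(=O)C1=C(C)NC(=O)NC1c1ccoc1` gives 2% in this assay. The step of a number 1 percentage points lower from compound 1 to compound 2 (within the scatter) stayed within the scatter. Compound 3 `CCN(CC)C(=O)C1=C(C)NC(=O)NC1c1ccoc1` differs from compound 2 by ethyl in place of hydrogen on an amide-type nitrogen. Among the compounds with values here, no measured step covers an ethyl added to this amide-type nitrogen, and the one step at hand, on the same carbonyl, showed no movement beyond the scatter, so no change beyond the scatter is expected, that is a number 1 percentage points higher from compound 2 to compound 3 (within the scatter). Compound 3 is estimated at 2%, with a range from -8% to 12%.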

Compound 3, a percentage reported as inhibition, at one concentration (the size of the read-out at that concentration, not a potency): 37%
Beside the measured number, compound 3's estimate is 35 percentage points below it, and the stated range ends below it.
By their numbers in this assay, from the lowest: compounds 2 and 1 (each within the scatter of the next); then compound 3.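

In this assay, the amide-type nitrogen turns out to be a place where a change registers: ethyl in place of hydrogen there gives a number 36 percentage points higher from compound 2 to compound 3 (beyond the scatter) and so moves the number far more than a number 1 percentage points lower from compound 1 to compound 2 (within the scatter) did earlier. Diethylamino in place of propyl on the carbonyl carbon gives a number 35 percentage points higher from compound 1 to compound 3 (beyond the scatter) as well, so diethylamino alone stands apart among the three groups on this carbonyl. Nothing available here accounts for the rise. Going by these compounds, whether dimethylamino or dipropylamino on the same carbonyl would give a similar number remains open, as does whether a longer chain would raise it further.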